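Urea series against TNNI3K: shifting the aminopyrimidine substituent

A few compounds are considered here, and "the series" means these few. Any claim that something is new, unique, unknown or untested is made for them only; others in the source may bear on it.

Compound 1 `Nc1cc(Oc2ccc(NC(=O)Nc3cccc(C(F)(F)F)c3)cc2)ncn1` and compound 2 `CCCNc1cc(Oc2ccc(NC(=O)Nc3cccc(C(F)(F)F)c3)cc2)ncn1` share a diaryl ether urea core and differ only at the amino group on the pyrimidine. In an assay on isolated protein for inhibition of serine/threonine-protein kinase TNNI3K (Homo sapiens) (on this read-out lower numbers stand for stronger inhibition and higher numbers for weaker inhibition), compound 1 gives 25 nM, and in this assay compound 2 gives 32 nM. The step of a 1.3-fold higher number from compound 1 to compound 2 (0.11 log units; within the scatter) shows that propyl in place of hydrogen on that nitrogen changes nothing beyond the scatter. Compound 2 therefore stands at the higher of the two numbers, yet within the scatter of compound 1.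

Compound 3 `CNc1nccc(Oc2ccc(NC(=O)Nc3cccc(C(F)(F)F)c3)cc2)n1` is the next member. Relative to compound 2 the change is 2-(methylamino)pyrimidin-4-yl in place of 6-(propylamino)pyrimidin-4-yl on an oxygen on an aromatic ring. For the measured compounds named here, only the step of a 1.3-fold higher number from compound 1 to compound 2 (0.11 log units; within the scatter) bears on it, and it covers solely the alkyl on the nitrogen, not the move of the amino group to another position of the pyrimidine. Going by the values given here, that move has no measured counterpart here, so the expectation rests on the core being kept intact. Compound 3 is expected to show a step of a 1.6-fold higher number from compound 2 to compound 3 (0.19 log units; within the scatter) in this assay, a modest weakening at most. Compound 3 is estimated at 50 nM, with a range from 10 nM to 250 nM.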

Compound 3, half-maximal inhibitory concentration: 50 nM
For compound 3 middle estimate and measured number coincide at the digits printed; the range from low to high includes it.
By their numbers in this assay, from the lowest: compounds 1, 2 and 3 (each within the scatter of the next).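

The earlier step spoke only to the alkyl on the nitrogen, whereas this result also covers the place of the amino group: 2-(methylamino)pyrimidin-4-yl in place of 6-(propylamino)pyrimidin-4-yl on an oxygen on an aromatic ring gives a 1.6-fold higher number from compound 2 to compound 3 (0.19 log units; within the scatter) in this assay. Measured against the unsubstituted amine, 2-(methylamino)pyrimidin-4-yl in place of 6-aminopyrimidin-4-yl gives a 2.0-fold higher number from compound 1 to compound 3 (0.30 log units; within the scatter), so both steps into compound 3 stay within the scatter of this read-out, with the core of compound 1 kept intact. No measured evidence is available to explain why this change at the pyrimidine leaves the number within the scatter.

The compounds shown leave open how much of these steps belongs to the place of the amino group and how much to the alkyl on it, as the two change together between compound 2 and compound 3; a 6-(methylamino)pyrimidin-4-yl group would separate them. Also open, from the compounds shown here alone, is whether a longer chain such as butyl, or a 2-hydroxyethyl group, on that nitrogen would stay within the scatter as well.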